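Swapping phenyl for amino: cytotoxicity of compound 3

A few compounds are considered here, and "the series" means these few. Any claim that something is new, unique, unknown or untested is made for them only; others in the source may bear on it.

Compound 1 `COC(=O)c1ccc(NCc2cncn2Cc2cccc([N+](=O)[O-])c2)cc1-c1ccccc1`: > 10000 nM
Compound 2 `COC(=O)c1ccc(NCc2cncn2Cc2ccccc2-c2ccccc2)cc1-c1ccccc1`: "not determined" (no result reported)

In a toxicity assay on NIH3T3 cells (Mus musculus) for cytotoxicity, read by resazurin assay (a higher number here means that more compound is needed for the effect, a lower number that less compound is needed), compound 2 has no number, and its entry reads "not determined" (no result reported). Compound 1 gives > 10000 nM, which is a limit of the assay and not a number. The only reference available is therefore (the limit of > 10000 nM in this assay, at which 1 of the 2 values shown sits).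

Compound 3 `COC(=O)c1ccc(NCc2cncn2Cc2ccccc2N)cc1-c1ccccc1` carries one structural change relative to compound 2: amino in place of phenyl on an aromatic carbon. This places amino in place of phenyl on an aromatic carbon, ortho to a large group. For the measured compounds named here, no measured step shows the size of such a change. With only compound 1 and its > 10000 nM to rest on, no step beyond the scatter is expected, and no direction can be favoured. For compound 3 the estimated value is 12000 nM, with an expected range of 4000 nM to 35000 nM.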

Compound 3, half-maximal effective concentration: 25000 nM
Compound 3: middle estimate off by 2.1-fold (0.32 log units), on the low side; low and high end bracket the measured number.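

No step can be read from compound 1 to compound 3 in this assay, as the value of compound 1 is a limit of the assay: the limit of > 10000 nM in this assay, at which 1 of the 3 values shown sits.

The compounds shown leave open how large a step amino in place of phenyl brings in this assay.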